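Para and meta chlorobenzoate esters of a shared core

The source may hold more compounds than are shown below. What is called first, only, known or untested is meant among the compounds shown, and "the series" means these compounds.

Measured compounds:
compound 1, `CC1=CC[C@H](C(C)C)c2cc(C)c(OC(=O)c3ccc(C(F)(F)F)cc3)cc21`, 9%
compound 2, `CC1=CC[C@H](C(C)C)c2cc(C)c(OC(=O)c3ccc(Cl)cc3)cc21`, 58.9%
compound 3, `CC1=CC[C@H](C(C)C)c2cc(C)c(OC(=O)c3cccc(Cl)c3)cc21`, reported as "not active" (no number reported), without a number

In a functional assay on K562 cells (Homo sapiens) for antiproliferative activity, read by sulforhodamine B assay, with a stated time of 48 h, tested at 50 uM (a higher number here means more inhibition at the concentration tested (going by the name of the read-out), a lower number less inhibition), compound 2 gives 58.9%, whereas compound 1 gives 9%. The change between them, (trifluoromethyl in place of chloro on an aromatic carbon), produces a number 49.9 percentage points lower from compound 2 to compound 1 (beyond the scatter). Compound 3 differs from compound 2 by 3-chlorophenyl in place of 4-chlorophenyl on a carbonyl carbon; for compound 3 no number is reported, only the verdict "not active" (no number reported). Compound 4, `CC1=CC[C@H](C(C)C)c2cc(C)c(OC(=O)c3cccc(C(F)(F)F)c3)cc21`, is not yet measured; it differs from compound 3 by trifluoromethyl in place of chloro on an aromatic carbon. This is the same kind of change as from compound 2 to compound 1, though the place differs: para to a large group in the one case, meta to a large group in the other. Since compound 3 is reported as "not active" (no number reported), no large downward step is expected, and a low number for compound 4 is expected, near the level compound 1 shows with 9%. Compound 4 is therefore estimated at 5%, between 0% and 20%.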

Compound 4, a percentage reported as inhibition, at one concentration (the size of the read-out at that concentration, not a potency): 45.5%
Compound 4: middle estimate off by 40.5 percentage points, on the low side; the measured number lies above the stated range.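

Among the compounds shown here, compound 3 carries only the verdict "not active" and no number, so no step from compound 3 to compound 4 can be read. The compounds shown leave open how far trifluoromethyl and chloro differ in this place. No measurement shown bears on the cause of the result for compound 4.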